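The source may hold more compounds than are shown below. What is called first, only, known or untested is meant among the compounds shown, and "the series" means these compounds.

In a functional assay on CHO-K1 cells for agonist activity at trace amine-associated receptor 1 (Homo sapiens), read by HTRF and cAMP accumulation, with a stated time of 30 min (a lower number here means a smaller maximal response, a higher number a larger maximal response), compound 2 `CNCC1OCCCc2ccsc21` gives 113%. Compound 1 `c1cc2c(s1)[C@H](CN1CCCC1)OCC2` gives 113% in this assay, so compound 2 stands level with compound 1, the two values lying within the scatter of each other. Compound 3 `NCC1OCCCc2ccsc21` differs from compound 2 in one place: hydrogen in place of methyl on an amine nitrogen. Going by the values given here, no step between two measured compounds is available to gauge such a change, and the two measured values give no trend. The step is therefore expected to be a number 8 percentage points lower from compound 2 to compound 3 (within the scatter), none beyond the scatter. Compound 3 is estimated to reach 105%, within a range from 85% to 125%.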

Compound 3, largest response reached (Emax), in percent of the reference or control that the assay uses: 111%
Compound 3: middle estimate off by 6 percentage points, on the low side; the range from low to high includes it.
By their numbers in this assay, from the lowest: compounds 3, 1 and 2 (each within the scatter of the next).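

Hydrogen in place of methyl on an amine nitrogen gives a number 2 percentage points lower from compound 2 to compound 3 (within the scatter) in this assay, the first reading of this change in the series. In this one pair, the maximal response does not depend on that methyl. No measured evidence accounts for this result. Going by these compounds, whether an ethyl group, a longer chain or a second methyl on the same nitrogen would keep this response remains open. So does whether hydrogen in place of methyl would read the same on another core.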